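Swapping a Methylfuran for an Ethylphenyl Ring

The compounds below may be only part of what the source reports. "The series", "measured", "known", "first", "only" and "open" are said of these compounds alone.

In an assay on Sf9 cells for inhibition of protein deacetylase HDAC6 (Homo sapiens), read by fluorescence, with a stated time of 40 min, tested at 100 nM (a higher number here means more inhibition at the concentration tested (going by the name of the read-out), a lower number less inhibition), compound 1 `Cc1ccc(-c2nc(CNc3ccc(C(=O)NO)cc3)n(-c3ccccc3)n2)o1` gives 60.7%, the second highest of the three numbers measured. Within the data shown here, compound 2 `O=C(NO)c1ccc(NCc2nc(-c3ccccc3)nn2-c2ccccc2Cl)cc1` gives 64.6%, a number within the scatter of the one for compound 1, so the two cannot be separated. Compound 3 `O=C(O)c1ccc(NCc2nc(-c3ccccc3)nn2-c2ccccc2)cc1` gives -0.4%, far below compound 1 and beyond the scatter. Among the measured compounds shown here, no two of these measured compounds differ in a single place, so no measured step is at hand.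

Compound 4 `CCc1ccc(-c2nc(CNc3ccc(C(=O)NO)cc3)n(-c3ccccc3)n2)cc1` is not yet measured. It differs from compound 1 in one place: 4-ethylphenyl in place of 5-methylfuran-2-yl on an aromatic carbon. That place lies on an aromatic carbon of the five-membered ring with three nitrogen atoms, between two ring nitrogen atoms.

Since compounds 1 and 2 give numbers within the scatter of each other, the change is expected to leave the number roughly where it is. The step from compound 1 to compound 4 is expected to be a number 1.3 percentage points higher from compound 1 to compound 4 (within the scatter), none beyond the scatter. Compound 4 is estimated to give 62%, with a range from 45% to 78%.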

Compound 4, a percentage reported as inhibition, at one concentration (the size of the read-out at that concentration, not a potency): 54.6%
Compound 4: middle estimate off by 7.4 percentage points, on the high side, within the range that was stated.
By their numbers in this assay, from the lowest: compound 3; then compounds 4, 1 and 2 (each within the scatter of the next).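

In this assay, putting 4-ethylphenyl in place of 5-methylfuran-2-yl gives a number 6.1 percentage points lower from compound 1 to compound 4 (within the scatter), so this aromatic carbon between two ring nitrogen atoms accepts the larger group, with 8 heavy atoms in place of 6, without a change that can be told from scatter. The entering group has a six-membered aromatic ring of carbon only and no hydrogen-bond acceptor, so for this pair neither the furan oxygen nor a five-membered ring is needed to keep the number within the scatter. No measurement shown explains why the two groups read alike.

As far as these compounds go, whether an amine or a carboxylic acid on the phenyl ring, or a longer chain in place of ethyl, would hold the number at this position remains open. Also open, from the compounds shown here alone, is how compound 1 and compound 4 compare in potency, as a reading at one concentration is not a potency.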